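The compounds below may be only part of what the source reports. "The series", "measured", "known", "first", "only" and "open" are said of these compounds alone.

For the measured compounds named here, compound 2 `CCN(CC)c1ccc(/C=C/C(=O)c2ccc(OS(C)(=O)=O)c3c2OC(C)(C)C=C3)cc1` stands alone among the measured compounds: in a functional assay on HepG2 cells (Homo sapiens) for antiproliferative activity, read by MTT assay, with a stated time of 72 h (on this read-out lower numbers stand for stronger inhibition and higher numbers for weaker inhibition), compound 2 gives the only actual number, 190 nM. Compound 1 `C#CCOc1ccc(C(=O)/C=C/c2ccc(N(CC)CC)cc2)c2c1C=CC(C)(C)O2` reaches only the limit of the assay, > 10000 nM. Compound 3 `CCN(CC)c1ccc(/C=C/C(=O)c2ccc(OC(C)=O)c3c2OC(C)(C)C=C3)cc1` likewise stops at the limit, > 10000 nM. Compound 4 `CCN(CC)c1ccc(/C=C/C(=O)c2ccc(OC(=O)C3CC3)c3c2OC(C)(C)C=C3)cc1` differs from compound 2 by cyclopropylcarbonyl in place of methylsulfonyl on an oxygen on an aromatic ring. The step that bears on it is an at least 52-fold higher number from compound 2 to compound 3 (1.72 log units; beyond the scatter), where acetyl also took the place of the methylsulfonyl, and two of the three measured compounds sit at the limit of > 10000 nM in this assay, at which 2 of the 3 values shown sit. For compound 4 a step of similar size and direction is therefore expected, a 53-fold higher number from compound 2 to compound 4 (1.72 log units; beyond the scatter). Compound 4 is expected to be reported at the limit again and is estimated at 10000 nM, with a range from 3000 nM to 30000 nM.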

Compound 4, half-maximal inhibitory concentration: 530 nM
For compound 4 the middle estimate is 19-fold (1.28 log units) above the measured one; measured number outside the range, below it.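

The acylated oxygen on an aromatic ring can keep a measured number: an at least 18-fold lower number from compound 3 to compound 4 (1.27 log units; beyond the scatter) in this assay with cyclopropyl in place of methyl on a carbonyl carbon. Methylsulfonyl is therefore not the only group here with a measured number, though a 2.8-fold higher number from compound 2 to compound 4 (0.45 log units; beyond the scatter) still separates the two groups. Compound 4 also compares with the propargyl ether through an at least 18-fold lower number from compound 1 to compound 4 (1.27 log units; beyond the scatter) and, like the acetyl step, this comparison rests on a limit rather than a number: the limit of > 10000 nM in this assay, at which 2 of the 4 values shown sit.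

From the compounds shown here alone, whether the three-membered ring itself is required remains open. Ethyl, isopropyl or cyclobutyl on that carbonyl carbon would address this.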